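The source may hold more compounds than are shown below. What is called first, only, known or untested is meant among the compounds shown, and "the series" means these compounds.

Among the compounds with values here, of the two compounds measured so far, compound 2 `Cc1ccc(-c2csc(NC(=O)COc3ccc(F)cc3)n2)cc1` holds the lower number in a functional assay on MDA-MB-468 cells (Homo sapiens) for cytotoxicity, read by trypan blue exclusion, with a stated time of 48 h; on this read-out lower numbers stand for stronger inhibition and higher numbers for weaker inhibition: in this assay compound 2 gives 24400 nM, whereas compound 1 `Cc1ccc(-c2csc(NC(=O)COc3ccccc3C)n2)cc1` gives 51700 nM. Within the data shown here, the single measured step, a 2.1-fold lower number from compound 1 to compound 2 (0.33 log units; beyond the scatter), lies beyond the scatter, but it altered the ring that hangs on the oxygen, not the ring attached to the shared core.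

Compound 3 `O=C(COc1ccc(F)cc1)Nc1nc(-c2ccc(Cl)cc2)cs1` differs from compound 2 by chloro in place of methyl on an aromatic carbon. Among the measured compounds shown here, this position was left untouched in the measured pair, so no measured step speaks directly to what a chloro in place of a methyl will do here. With nothing to fix a direction, the expected step from compound 2 to compound 3 is one that stays within the scatter, a 1.2-fold lower number from compound 2 to compound 3 (0.09 log units; within the scatter). Compound 3 is therefore estimated at 20000 nM, with a range from 7000 nM to 60000 nM.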

Compound 3, half-maximal inhibitory concentration: 42900 nM
For compound 3 the middle estimate is 2.1-fold (0.33 log units) below the measured one, within the range that was stated.
By their numbers in this assay, from the lowest: compounds 2, 3 and 1 (each within the scatter of the next, the first and the last beyond it).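

Within the data shown here, this is the first look at the ring attached to the shared core, as opposed to the ring on the oxygen. In this assay, chloro in place of methyl on an aromatic carbon, para to a large group, gives a 1.8-fold higher number from compound 2 to compound 3 (0.25 log units; within the scatter). With the 4-fluorophenyl on the oxygen held constant, 4-methylphenyl and 4-chlorophenyl therefore cannot be told apart at this position, and nothing available explains why these two groups read alike.

Methyl and chloro each count as one heavy atom, so it remains open whether a larger or very different group here, such as an amine, a carboxylic acid or a longer chain, would shift the number beyond the scatter. Going by these compounds, it is also open whether chloro and methyl would still read alike with the 2-methylphenyl of compound 1 on the oxygen.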